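The source may report more compounds than this note shows. Statements on the series, on what has been measured and on what is new or still open speak of the compounds shown alone.

Of the compounds shown here, three built on one shared core have been measured in a functional assay on ECa-109 cells (Homo sapiens) for inhibition, read by MTT assay, with a stated time of 72 h; a lower number here means a stronger inhibitor, a higher number a weaker inhibitor. Compound 1 `S=C(SCc1cn(Cc2ccccc2Cl)nn1)N1CCNCC1` gives only a limit of the assay there, > 128000 nM. Compound 2 `Fc1ccccc1Cn1cc(CSC(=S)N2CCNCC2)nn1` likewise returns a limit rather than a number in this assay, > 128000 nM. Compound 3 `Cc1ccc(Cn2cc(CSC(=S)N3CCNCC3)nn2)cc1`, the starting point of this account, also yields a limit in this assay and no number, > 128000 nM. The steps among the three are accordingly unreadable: a step that the two limits leave unreadable from compound 1 to compound 2, a step that the two limits leave unreadable from compound 1 to compound 3 and a step that the two limits leave unreadable from compound 2 to compound 3, each of them unreadable since all three values sit at the limit of > 128000 nM in this assay, at which 3 of the 3 values shown sit. Compound 3 thus stands exactly where compounds 1 and 2 stand, without a number to rank it against either.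

Compound 4 `COc1ccc(Cn2cc(CSC(=S)N3CCNCC3)nn2)cc1` differs from compound 3 in a single place: methoxy in place of methyl on an aromatic carbon. Going by the values given here, none of the measured steps bears on this change in a readable way; they show only that exchanging the group bound to the aromatic nitrogen of the core left every compound without a number in this assay. The expectation for compound 4 is therefore that it, too, most likely returns only a limit, and the step that the limit leaves unreadable from compound 3 to compound 4 is expected to be nothing beyond the scatter. Compound 4 is estimated at 200000 nM, within a range from 64000 nM to 1000000 nM.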

Compound 4, half-maximal inhibitory concentration: > 128000 nM
Compound 4: no number, only a limit; the forecaster's own chance of this, stated with the estimate: 85%; the middle value is on the limit's open side.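

In this assay compound 4 gives only a limit (> 128000 nM). The steps to compound 4 from compound 1, compound 2 and compound 3 therefore cannot be read: the limit of > 128000 nM in this assay, at which 4 of the 4 values shown sit. The compounds shown leave open how these four rank against one another, and whether any change on the shared core would give a number in this assay.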